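One Methyl Added Twice on the Same Oxygen

A few compounds are considered here, and "the series" means these few. Any claim that something is new, unique, unknown or untested is made for them only; others in the source may bear on it.

Compound 1 `O=C(Nc1cccc(-n2cc(-c3ccncc3)c(-c3cc(O)cc(Cl)c3)n2)c1)Nc1ccc(Cl)c(Cl)c1` and compound 2 `COc1cc(Cl)cc(-c2nn(-c3cccc(NC(=O)Nc4ccc(Cl)c(Cl)c4)c3)cc2-c2ccncc2)c1` share one core and differ in a single place: methyl in place of hydrogen on an oxygen on an aromatic ring. In a functional assay on HCT-15 cells (Homo sapiens) for inhibition, read by sulforhodamine B assay, with a stated time of 48 h, tested at 10 uM (a lower number here means a stronger effect, a higher number a weaker effect of the compound at the concentration tested), compound 1 gives -25.3%, and compound 2 gives 13.9%; the step of a number 39.2 percentage points higher from compound 1 to compound 2 (beyond the scatter) is a large weakening. Compound 3 `O=C(Nc1cccc(-n2cc(-c3ccncc3)c(-c3cc(O)cc(Cl)c3)n2)c1)c1cc(C(F)(F)F)cc(C(F)(F)F)c1` rests on another core; the difference between the cores of compound 1 and compound 3 is not broken down here. In this assay compound 3 gives 30.1%. Compound 4 `COc1cc(Cl)cc(-c2nn(-c3cccc(NC(=O)c4cc(C(F)(F)F)cc(C(F)(F)F)c4)c3)cc2-c2ccncc2)c1` arises from compound 3 by the same change, (methyl in place of hydrogen on an oxygen on an aromatic ring), at a place described in identical words. Resting on the single precedent a number 39.2 percentage points higher from compound 1 to compound 2 (beyond the scatter), the step of a number 27.9 percentage points higher from compound 3 to compound 4 (beyond the scatter) is expected for compound 4, in the same weakening direction but with wide uncertainty from one example. Compound 4 is therefore estimated at 58%, between 30% and 85%.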

Compound 4, a percentage reported as activity, at one concentration (the size of the read-out at that concentration, not a potency): 58.6%
Beside the measured number, compound 4's estimate is 0.6 percentage points below it, and the stated range covers the measured number.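

In this assay, adding the methyl to the oxygen on the second core gives a step of a number 28.5 percentage points higher from compound 3 to compound 4 (beyond the scatter) in the same weakening direction as on the first. Set side by side, the two steps do not differ beyond what repeated measurements allow: the same change on two cores in this assay, a number 39.2 percentage points higher (beyond the scatter) from compound 1 to compound 2 and a number 28.5 percentage points higher (beyond the scatter) from compound 3 to compound 4, 10.7 percentage points apart, within the scatter of two such steps. This shows that hydroxy to methoxy carried across these two cores at the single concentration tested, but two cores cannot show that it holds on any other core, and they do not explain the weakening.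

As far as these compounds go, what an amine or an ethoxy group in place of the hydroxy would do remains open. So does whether the hydroxy itself is needed for the stronger effect on other cores.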